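Fluoro to Nitro Beside a Methanesulfonamido Group

A few compounds are considered here, and "the series" means these few. Any claim that something is new, unique, unknown or untested is made for them only; others in the source may bear on it.

Measured compounds:
compound 1, `CC(C)(C)c1ccc(CCC/N=C(\S)NCc2ccc(NS(C)(=O)=O)c(F)c2)cc1`: 2000 nM
compound 2, `CS(=O)(=O)Nc1ccc(C/N=C(\S)NC(c2ccccc2)c2ccccc2)cc1F`: 2500 nM
compound 3, `CC(C)(C)c1ccc(CNC(=O)NCc2ccc(NS(C)(=O)=O)c(F)c2)cc1`: 300 nM

In an assay for inhibition of transient receptor potential cation channel subfamily V member 1 (Rattus norvegicus), with a stated time of 10 min (on this read-out higher numbers stand for weaker inhibition and lower numbers for stronger inhibition), compound 3 gives the lowest number of the three and is therefore the strongest inhibitor here; compound 1 comes nearest, compound 2 sits furthest away, both beyond the scatter.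

Compound 4, `CC(C)(C)c1ccc(CNC(=O)NCc2ccc(NS(C)(=O)=O)c([N+](=O)[O-])c2)cc1`, is not yet measured. It differs from compound 3 in one place: nitro in place of fluoro on an aromatic carbon. Going by the values given here, no measured pair among compounds 1 to 3 shows this exchange, so its effect cannot be read from the data. A group of three heavy atoms replaces a single atom on the ring that carries the methanesulfonamido group, and nothing here tells whether that helps or hurts. The expected step from compound 3 to compound 4 in this assay is a 1.7-fold higher number from compound 3 to compound 4 (0.22 log units; within the scatter), a slight weakening that stays within the scatter. Compound 4 is therefore estimated at 500 nM, with a range from 150 nM to 1700 nM.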

Compound 4, half-maximal inhibitory concentration: 240 nM
Compound 4: the middle estimate sits 2.1-fold (0.32 log units) above what was measured, within the range that was stated.
By their numbers in this assay, from the lowest: compounds 4 and 3 (each within the scatter of the next); then compounds 1 and 2 (each within the scatter of the next).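

At the aromatic carbon ortho to a methanesulfonamido group, nitro in place of fluoro gives a 1.3-fold lower number from compound 3 to compound 4 (0.10 log units; within the scatter) in this assay, so the two compounds cannot be told apart on this read-out. This position can therefore hold nitro, with its 3 heavy atoms and 2 hydrogen-bond acceptors, in place of fluoro, with its 1 heavy atom and none, without a change in inhibition that stands out from the scatter. No measurement shown explains why these two groups read alike.

From the compounds shown here alone, whether an amine, a nitrile or a methoxy group at this position would also read alike remains open. So does whether the same exchange would give a similar result on the cores of compound 1 and compound 2.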